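The compounds below may be only part of what the source reports. "The series", "measured", "known", "first", "only" and "open" are said of these compounds alone.

Compound 3 `Cn1ncc2c(NC(=O)NCc3cc(C(C)(C)C)nn3-c3ccc(Cl)cc3)cccc21` has the highest number of the three compounds measured in an assay on CHO-K1 cells for antagonist activity at transient receptor potential cation channel subfamily V member 1 (Homo sapiens), read by FLIPR and calcium flux, with a stated time of 6 min; a higher number here means a weaker inhibitor, a lower number a stronger inhibitor: compound 3 gives 9.5 nM, while compound 1 `Cn1ncc2c(NC(=O)NCc3cc(C(C)(C)C)nn3-c3cccc(Cl)c3)cccc21` gives 0.4 nM and compound 2 `CC(C)(C)c1cc(CNC(=O)Nc2cccc3[nH]ncc23)n(-c2ccc(F)cc2)n1` gives 2.2 nM. Among the measured compounds shown here, the one step that shows a single change, a 24-fold higher number from compound 1 to compound 3 (1.38 log units; beyond the scatter), concerns where the chlorine sits on the phenyl ring, not its identity, so it does not bear on the change considered here. Compound 4 `Cn1ncc2c(NC(=O)NCc3cc(C(C)(C)C)nn3-c3ccc(F)cc3)cccc21` differs from compound 3 only in fluoro in place of chloro on an aromatic carbon. For the measured compounds named here, no measured pair shows this swap of one halogen for another on an otherwise unchanged scaffold. Compound 2 carries the same 4-fluorophenyl as compound 4 but on a different core, so its value can only hint that a fluorine at this position is compatible with a low number. Going by the values given here, with no direct precedent, the step from compound 3 to compound 4 is expected to stay within the scatter, a 1.2-fold lower number from compound 3 to compound 4 (0.07 log units; within the scatter), and compound 4 is estimated at 8 nM in this assay, with a likely range of 2.5 nM to 25 nM.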

Compound 4, inhibition constant: 4.5 nM
Beside the measured number, compound 4's estimate is 1.8-fold (0.25 log units) above it; low and high end bracket the measured number.
By their numbers in this assay, from the lowest: compound 1; then compound 2; then compound 4; then compound 3.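

In this assay, fluoro in place of chloro on the phenyl ring, para to a large group, gives a 2.1-fold lower number from compound 3 to compound 4 (0.32 log units; beyond the scatter) and so shows that the choice of halogen at this place changes the number, though only modestly. With the 4-fluorophenyl kept, methyl in place of hydrogen on the aromatic nitrogen gives a 2.0-fold higher number from compound 2 to compound 4 (0.31 log units; beyond the scatter) as a second modest step. The halogen swap recovers only a small part of the large rise seen in a 24-fold higher number from compound 1 to compound 3 (1.38 log units; beyond the scatter) and leaves an 11-fold higher number from compound 1 to compound 4 (1.05 log units; beyond the scatter) as a large gap to the best compound here.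

The compounds shown leave open how a bromo or methoxy group would read at this place, and whether a 3-fluorophenyl would give a number as low as the 3-chlorophenyl of compound 1. Nothing measured here says why fluoro gives the lower number.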